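Two Placements of One Substituent Swap at a Serotonin Receptor

The compounds below may be only part of what the source reports. "The series", "measured", "known", "first", "only" and "open" are said of these compounds alone.

Compound 1 `CN(C)c1cccc2c1ccn2S(=O)(=O)c1ccccc1` was tested in an assay on isolated protein for displacement of a labelled ligand from 5-hydroxytryptamine receptor 6 (Homo sapiens), read by scintillation counting, with a stated time of 1 h (on this read-out lower numbers stand for stronger inhibition and higher numbers for weaker inhibition), where compound 1 gives 65 nM. Compound 2 `O=S(=O)(c1ccccc1)n1ccc2c(-c3ccccc3)cccc21` differs from it by phenyl in place of dimethylamino on an aromatic carbon, and in this assay compound 2 gives 162 nM, so that change produced a 2.5-fold higher number from compound 1 to compound 2 (0.40 log units; beyond the scatter). Compound 3 `CN(C)c1ccc2c(ccn2S(=O)(=O)c2ccccc2)c1` is built from the same atoms as compound 1, joined differently; the difference between the two cores is not broken down here. In this assay compound 3 gives 82 nM, a value within the usual scatter of compound 1.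

Compound 4 `O=S(=O)(c1ccccc1)n1ccc2cc(-c3ccccc3)ccc21` has not yet been measured. It differs from compound 3 by phenyl in place of dimethylamino on an aromatic carbon. Among the measured compounds shown here, this is the same kind of change as the one from compound 1 to compound 2, but not the same: there the place was ortho to a fused ring and meta to a fused ring, whereas here it is meta to a fused ring and para to a fused ring. With a single earlier example as guide, a step of similar size is expected, a 2.4-fold higher number from compound 3 to compound 4 (0.39 log units; beyond the scatter), because the earlier change gave a 2.5-fold higher number from compound 1 to compound 2 (0.40 log units; beyond the scatter). Compound 4 is therefore estimated to give 200 nM in this assay, with a plausible range from 80 nM to 500 nM.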

Compound 4, inhibition constant: 558 nM
For compound 4 the middle estimate is 2.8-fold (0.45 log units) below the measured one, outside the stated range (above it).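

In this assay, putting phenyl in place of dimethylamino again moved the result in the direction of weaker inhibition, with a 6.8-fold higher number from compound 3 to compound 4 (0.83 log units; beyond the scatter), so the direction of the change held on both cores. Among the compounds shown here, the size of the step did not hold, so a step measured on one core is only a rough guide to the same swap on the other: the same change on two cores in this assay, a 2.5-fold higher number (0.40 log units; beyond the scatter) from compound 1 to compound 2 and a 6.8-fold higher number (0.83 log units; beyond the scatter) from compound 3 to compound 4, 2.7-fold (0.44 log units) apart, beyond the scatter of two such steps With only two pairs, this shows that the effect of the swap depends on where it is made in these related cores, but it does not show why, and it offers no general rule for the series.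

The compounds shown leave open whether a primary amine or a methoxy group in place of dimethylamino would also give steps that differ between the two cores. They also leave open whether a longer chain on the amine nitrogen would behave more like dimethylamino or more like phenyl at each place.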